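The compounds below may be only part of what the source reports. "The series", "measured", "known", "first", "only" and "open" are said of these compounds alone.

In a functional assay on MGC-803 cells (Homo sapiens) for cytotoxicity, read by MTT assay, with a stated time of 38 h (on this read-out higher numbers stand for weaker inhibition and lower numbers for stronger inhibition), compound 1 (`COc1cc(OC)c2c(=O)c(OCCCCN3CCCC3)c(-c3cc(OC)c(OC)c(OC)c3)oc2c1`) stands at 18600 nM while compound 2 (`COc1cc(OC)c2c(=O)c(OCC(=O)N/N=C/c3ccc(C)cc3)c(-c3cc(OC)c(OC)c(OC)c3)oc2c1`) stands at 3510 nM and compound 3 (`COc1cc(OC)c2c(=O)c(OCC(=O)N/N=C/c3ccc[nH]3)c(-c3cc(OC)c(OC)c(OC)c3)oc2c1`) at 5610 nM on the same read-out. Compound 2 thus belongs to the lower pair: a 5.3-fold lower number from compound 1 to compound 2 (0.72 log units; beyond the scatter) clears the scatter, whereas a 1.6-fold higher number from compound 2 to compound 3 (0.20 log units; within the scatter) does not. Compound 4 (`COc1cc(OC)c2c(=O)c(OCC(=O)N/N=C/c3ccco3)c(-c3cc(OC)c(OC)c(OC)c3)oc2c1`) carries furan-2-yl in place of 4-methylphenyl on a carbon with a double bond to nitrogen. The step to compound 3 bears most closely on this, since it also puts a five-membered aromatic ring with 1 hetero atom at that carbon, while a 3.3-fold lower number from compound 1 to compound 3 (0.52 log units; beyond the scatter) replaces far more. The change in this assay is therefore expected to stay within the scatter (a 1.4-fold higher number from compound 2 to compound 4 (0.14 log units; within the scatter)). Compound 4 is estimated at 4800 nM within an expected range of 2400 nM to 9600 nM on this evidence.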

Compound 4, half-maximal inhibitory concentration: 6050 nM
Compound 4: middle estimate off by 1.3-fold (0.10 log units), on the low side; low and high end bracket the measured number.
By their numbers in this assay, from the lowest: compounds 2, 3 and 4 (each within the scatter of the next); then compound 1.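

At the carbon with a double bond to nitrogen, furan-2-yl stays within the scatter of both 4-methylphenyl (a 1.7-fold higher number from compound 2 to compound 4 (0.24 log units; within the scatter)) and 1H-pyrrol-2-yl (a 1.1-fold higher number from compound 3 to compound 4 (0.03 log units; within the scatter)) in this assay, so three different aromatic rings at this place give no separable numbers. The furan-2-yl compound also stands apart from compound 1 (a 3.1-fold lower number from compound 1 to compound 4 (0.49 log units; beyond the scatter)), as the other two compounds do. Nothing available explains these numbers. The compounds shown leave open whether a phenyl ring bearing an amine or a carboxylic acid at that carbon, or a longer chain there, would move the number beyond the scatter.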